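Swapping a branched chain for a small ring on a pyrazine core

The compounds below may be only part of what the source reports. "The series", "measured", "known", "first", "only" and "open" are said of these compounds alone.

From the compounds shown here alone, compound 1, `CC(C)(C)Nc1nc(N)c(C(=O)N=C(N)N)nc1Cl`, has in an assay for inhibition of acid-sensing ion channel 3 (Homo sapiens), read by patch clamp, tested at 1 uM (a higher number here means more inhibition at the concentration tested (going by the name of the read-out), a lower number less inhibition), only the entry "not determined" (no result reported), so its own level of inhibition is unknown. A related compound, compound 2, `NC(N)=NC(=O)c1nc(Cl)c(NCC2CCCCC2)nc1N`, carries a cyclohexylmethylamino group in place of the (tert-butyl)amino group, and in this assay compound 2 gives 28%. Compound 3, `NC(N)=NC(=O)c1nc(Cl)c(N2CCCC2)nc1N`, has not yet been tested. Compound 3 differs from compound 1 by pyrrolidin-1-yl in place of (tert-butyl)amino on an aromatic carbon; the group that enters has the same count of heavy atoms but loses its one hydrogen-bond donor. Going by the values given here, with no measured pair sharing this change, the size and direction of the step cannot be taken from the data, and nothing beyond the scatter is assumed. Among the compounds with values here, on the single value available, that of compound 2 at 28%, compound 3 is expected to give about 25% in this assay, estimated to lie between 5% and 50%.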

Compound 3, a percentage reported as inhibition, at one concentration (the size of the read-out at that concentration, not a potency): 12%
For compound 3 the middle estimate is 13 percentage points above the measured one; low and high end bracket the measured number.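

In this assay, going by these compounds alone, compound 1 has the entry "not determined" (no result reported) and compound 3 gives 12%, so no step from one to the other can be read. From the compounds shown here alone, whether pyrrolidin-1-yl in place of (tert-butyl)amino raises, lowers or leaves inhibition unchanged stays open. No supporting data bear on this result.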